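The source may hold more compounds than are shown below. What is called first, only, known or untested is meant among the compounds shown, and "the series" means these compounds.

Series notes. Compound 1 `COc1ncnc2c1c(I)cn2[C@@H]1O[C@H](CO)[C@@H](O)[C@H]1O` is run in a functional assay on HCT-116 cells (Homo sapiens), read by MTT assay, with a stated time of 72 h; on this read-out lower numbers stand for stronger inhibition and higher numbers for weaker inhibition. In this assay compound 1 returns only the assay limit, > 20000 nM. Compound 2 `Nc1nc2c(c(-c3ccccc3)cn2[C@@H]2O[C@H](CO)[C@@H](O)[C@H]2O)c(=O)[nH]1` likewise returns only the limit in this assay, > 20000 nM. Compound 1 therefore stands at the limit of > 20000 nM in this assay, at which 2 of the 2 values shown sit, with no number beyond it. Compound 3 `COc1ncnc2c1c(-c1cc3ccccc3o1)cn2[C@@H]1O[C@H](CO)[C@@H](O)[C@H]1O` differs from compound 1 by 1-benzofuran-2-yl in place of iodo on an aromatic carbon. Going by the values given here, no measured step covers this change, and the expectation rests on the limit alone. The expected step is an at least 3.3-fold lower number from compound 1 to compound 3 (0.52 log units; beyond the scatter), toward stronger inhibition, with a real chance that only a limit is returned again. Compound 3 is estimated at 6000 nM, within a range of 800 nM to 20000 nM.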

Compound 3, half-maximal inhibitory concentration: 14500 nM
Beside the measured number, compound 3's estimate is 2.4-fold (0.38 log units) below it; measured number inside the range.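

Going by these compounds alone, compound 3 is the first compound here to return a number rather than the limit in this assay, so this aromatic carbon can carry 1-benzofuran-2-yl, with its 9 heavy atoms, and still give a readable value. The change from iodo reads as an at least 1.3-fold lower number from compound 1 to compound 3 (0.13 log units; that floor lies within the scatter) and so sets only a floor on the size of the step. The limit still holds most of the series: the limit of > 20000 nM in this assay, at which 2 of the 3 values shown sit.

From the compounds shown here alone, whether an amine or a carboxylic acid at this carbon would move the number further remains open. So does whether 1-benzofuran-2-yl would give a number on the core of compound 2.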